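This account rests on a few compounds, and the source may have more. Where it says the series, first, only, none or still open, it means among the compounds named here.

In a physicochemical assay for solubility, in phosphate buffer, at pH 7.4 (a lower number here means a less soluble compound, a higher number a more soluble compound), compound 1 `CCCn1c(=O)c2nc(-c3ccccc3N)[nH]c2n(CCC)c1=O` gives < 1 ug/mL, which is a limit of the assay and not a number. Compound 2 `CCn1c(=O)c2nc(-c3ccc(S(=O)(=O)NCCN(C)C)cc3)[nH]c2n(CC)c1=O` gives 110 ug/mL in this assay, and that reading is a true number. Compound 3 `CCCn1c(=O)c2nc(-c3ccc(Cl)cc3N)[nH]c2n(CCC)c1=O` follows from compound 1 with chloro in place of hydrogen on an aromatic carbon, so that 2-aminophenyl becomes 2-amino-4-chlorophenyl (chloro in place of hydrogen on an aromatic carbon). For the measured compounds named here, no pair of measured compounds shows this change, so the expectation in this assay is only a small downward step, possibly no larger than the scatter. That expectation starts from compound 1, which sits at the limit of < 1 ug/mL in this assay, at which 1 of the 2 values shown sits. The estimated step that the limit leaves unreadable from compound 1 to compound 3 is therefore modest, and the reading may again be only a limit. Compound 3 is expected at 0.5 ug/mL, with an estimated range from 0.1 ug/mL to 2 ug/mL.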

Compound 3, solubility: < 0.1 ug/mL
Compound 3: only a limit was reported (the forecaster's own chance of this, stated with the estimate: 80%); middle value at least 5.0-fold (0.69 log units) away from the limit.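

Compound 1 and compound 3 are both reported only as limits of the assay in this assay, so no step can be read between them. The compounds shown leave open how large any difference between 2-aminophenyl and 2-amino-4-chlorophenyl is in this assay.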